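(Diethylamino)methyl in place of formyl: working notes

The compounds below may be only part of what the source reports. "The series", "measured", "known", "first", "only" and "open" are said of these compounds alone.

Measured so far in an ADME assay on A549 cells (Homo sapiens) for cytotoxicity, read by MTT assay; on this read-out lower numbers stand for stronger inhibition and higher numbers for weaker inhibition:
- compound 1 `O=CC1=C(Cl)c2cc(Cl)ccc2SC1` gives > 100 ug/mL as a limit
- compound 2 `O=CC1=C(Cl)c2cc(Br)ccc2SC1` gives > 100 ug/mL as a limit
- compound 3 `CCN(CC)CC1=C(Cl)c2cc(Cl)ccc2SC1` is still to be measured

Compound 1 stands at > 100 ug/mL in this assay and this is a limit, not a number. The move to compound 3 is (diethylamino)methyl in place of formyl on a double-bonded ring carbon and in words puts (diethylamino)methyl in place of formyl on a double-bonded ring carbon. Going by the values given here, the only measured step is a step that the two limits leave unreadable from compound 1 to compound 2 and it involves bromo in place of chloro on an aromatic carbon, with the formyl left in place. It therefore gives no size to carry over. Among the compounds with values here, all the series offers is the limit of > 100 ug/mL in this assay, at which 2 of the 2 values shown sit, and no measured step bears directly on this change.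

A readable result for compound 3 could only lie on the stronger side of compound 1 at > 100 ug/mL as a limit. A step towards lower numbers is therefore expected, though its size is poorly grounded and a second limit remains possible. an at least 2.2-fold lower number from compound 1 to compound 3 (0.34 log units; beyond the scatter) is the estimated step on this expectation. For compound 3 an estimated 45 ug/mL is expected and the range runs from 12 ug/mL to 100 ug/mL as estimated here.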

Compound 3, half-maximal inhibitory concentration: > 100 ug/mL
Compound 3 gave a limit, no number (the forecaster's own chance of this, stated with the estimate: 40%); middle value at least 2.2-fold (0.34 log units) away from the limit.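

In this assay compound 3 gives > 100 ug/mL, which is a limit and not a number. Going by these compounds alone, compound 1 also stands at a limit, so no step from it to compound 3 can be read. The compounds shown leave open whether any change on the shared core gives a readable value: the limit of > 100 ug/mL in this assay, at which 3 of the 3 values shown sit.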